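Furan to phenyl on the amide side chain

The compounds below may be only part of what the source reports. "The series", "measured", "known", "first", "only" and "open" are said of these compounds alone.

Measured compounds:
compound 1, `N[C@H]1CC[C@H](Nc2c(C(=O)NCc3ccco3)nc(Br)c3cccnc23)CC1`; compound 2, `N[C@H]1CC[C@H](Nc2c(C(=O)NCc3ccc(Cl)cc3)nc(Br)c3cccnc23)CC1`

In a functional assay on HEY cells (Homo sapiens) for cytotoxicity, read by MTT assay, with a stated time of 72 h (a higher number here means a weaker inhibitor, a lower number a stronger inhibitor), compound 1 gives > 10000 nM; this is a limit of the assay, not a number, so compound 1 stands only at the limit of > 10000 nM in this assay, at which 1 of the 2 values shown sits, and no fixed value is known for it. In this assay compound 2 gives 1000 nM. Among the measured compounds shown here, the one measured step, an at least 10-fold lower number from compound 1 to compound 2 (1.00 log units; beyond the scatter), is the only guide for the present change.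

Compound 3, `N[C@H]1CC[C@H](Nc2c(C(=O)NCc3ccccc3)nc(Br)c3cccnc23)CC1`, is not yet measured in this assay. It differs from compound 1 as follows: phenyl in place of furan-2-yl on a saturated chain carbon bound to an amide-type nitrogen. This is the same place as the measured step, but the entering group is phenyl rather than 4-chlorophenyl, so the step from compound 1 to compound 2 bears on it only in part.

On this basis compound 3 is expected to move in the same direction as compound 2, though less far. The estimated step for compound 3 is an at least 3.3-fold lower number from compound 1 to compound 3 (0.52 log units; beyond the scatter). The estimate for compound 3 in this assay is 3000 nM, with a range from 1000 nM to 10000 nM.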

Compound 3, half-maximal inhibitory concentration: 8000 nM
Beside the measured number, compound 3's estimate is 2.7-fold (0.43 log units) below it; low and high end bracket the measured number.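

In this assay, taking away the chloro group gives an 8.0-fold higher number from compound 2 to compound 3 (0.90 log units; beyond the scatter), so the gain at compound 2 cannot be credited to the change of ring alone; the chloro group on the aromatic carbon has a clear part in it. Phenyl in place of furan-2-yl on the same saturated chain carbon gives an at least 1.2-fold lower number from compound 1 to compound 3 (0.09 log units; that floor lies within the scatter), and this is only a floor for the step, one that lies within the scatter. Compound 1 has a limit of the assay and not a number, so the full size of that step cannot be read, because of where compound 1 stands: the limit of > 10000 nM in this assay, at which 1 of the 3 values shown sits.

From the compounds shown here alone, it remains open whether the gain belongs to chloro in particular, or whether fluoro, methyl, methoxy or trifluoromethyl on the phenyl ring would give a similar step, and whether chloro on the furan-2-yl ring would also lower the number. Also open, going by these compounds, is how a pyridyl ring in place of phenyl, or a longer chain between the amide nitrogen and the ring, would read in this assay.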